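Ester series: phenoxy in place of trifluoromethyl

The source may hold more compounds than are shown below. What is called first, only, known or untested is meant among the compounds shown, and "the series" means these compounds.

Measured so far:
compound 1 `O=C(OCc1cccc(C(F)(F)F)c1)c1cccc(=O)[nH]1`: > 150 nM
compound 2 `O=C(OCc1ccc(Cl)cc1)c1cccc(=O)[nH]1`: 68000 nM
compound 3 `O=C(OCCOc1ccccc1)c1cccc(=O)[nH]1`: 127000 nM

In an assay on isolated protein for inhibition of matrix metalloproteinase-9 (Homo sapiens) (on this read-out higher numbers stand for weaker inhibition and lower numbers for stronger inhibition), compound 1 gives only a limit, > 150 nM, and not a number. Compound 1 thus sits at the limit of > 150 nM in this assay, at which 1 of the 3 values shown sits. In this assay compound 2 gives 68000 nM, and compound 3 gives 127000 nM; both are weak, and the two values lie within the usual scatter of each other.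

Compound 4 `O=C(OCc1cccc(Oc2ccccc2)c1)c1cccc(=O)[nH]1` is the next compound for this assay. It differs from compound 1 in one place: phenoxy in place of trifluoromethyl on an aromatic carbon. Among the compounds with values here, no measured step exists for this change. From the weak values of compound 2 and compound 3, compound 4 is expected to stay weak, and the step that the limit leaves unreadable from compound 1 to compound 4 is an estimate only. For compound 4 the expected value is 50000 nM, with a range from 5000 nM to 200000 nM.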

Compound 4, half-maximal inhibitory concentration: > 150 nM
Compound 4 was reported as a limit (the forecaster's own chance of this, stated with the estimate: 25%); the middle value lies beyond the limit too.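

Compound 1 and compound 4 are both reported only as limits in this assay, so the step between them cannot be read: the limit of > 150 nM in this assay, at which 2 of the 4 values shown sit.

The compounds shown leave open whether phenoxy in place of trifluoromethyl on an aromatic carbon changes inhibition at all.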